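A few compounds are considered here, and "the series" means these few. Any claim that something is new, unique, unknown or untested is made for them only; others in the source may bear on it.

Measured so far in a functional assay on HeLa cells (Homo sapiens) for inhibition, read by MTT assay, with a stated time of 72 h; a lower number here means a stronger inhibitor, a higher number a weaker inhibitor:

- compound 1 `O=c1cc(Cn2cc(C3CC3)nn2)c2ccc(O)cc2o1` gives > 100000 nM
- compound 2 `O=c1cc(Cn2cc(CCCO)nn2)c2ccc(O)cc2o1` gives 90200 nM
- compound 3 `O=c1cc(Cn2cc(CCc3ccccc3)nn2)c2ccc(O)cc2o1` gives 35100 nM

The value for compound 1 is a limit of this assay, not a number (the limit of > 100000 nM in this assay, at which 1 of the 3 values shown sits). Compound 2 therefore stands highest of the two numbers shown; its nearest neighbour is compound 3, with a 2.6-fold lower number from compound 2 to compound 3 (0.41 log units; beyond the scatter). Against the limit of compound 1, an at least 1.1-fold lower number from compound 1 to compound 2 (0.04 log units; that floor lies within the scatter) and an at least 2.8-fold lower number from compound 1 to compound 3 (0.45 log units; beyond the scatter) are known only as floors.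

Compound 4 `O=c1cc(Cn2cc(-c3ccc(Br)cc3)nn2)c2ccc(O)cc2o1` differs from compound 2 in one place: 4-bromophenyl in place of 3-hydroxypropyl on an aromatic carbon. The measured step that bears most directly on it is a 2.6-fold lower number from compound 2 to compound 3 (0.41 log units; beyond the scatter), where a phenyl replacing a hydroxymethyl on the saturated chain lowered the number by a modest amount. The step of an at least 2.8-fold lower number from compound 1 to compound 3 (0.45 log units; beyond the scatter) points the same way, at least modestly, while an at least 1.1-fold lower number from compound 1 to compound 2 (0.04 log units; that floor lies within the scatter) lies within the scatter. Among the measured compounds shown here, compound 4 goes further than compound 3 in that the chain is removed and the aromatic ring sits directly on the core carbon, with bromine on it; no measured pair covers that exactly. A modest lowering, of about the size seen with compound 3, is expected, with wide uncertainty. For compound 4 the estimate in this assay is 30000 nM, between 8000 nM and 100000 nM, which corresponds to an expected step of a 3.0-fold lower number from compound 2 to compound 4 (0.48 log units; beyond the scatter).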

Compound 4, half-maximal inhibitory concentration: 40200 nM
Estimate against measurement, compound 4: 1.3-fold (0.13 log units) below, and the stated range covers the measured number.
By their numbers in this assay, from the lowest: compounds 3 and 4 (each within the scatter of the next); then compound 2. At a limit, above all of these: compound 1.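

Working notes on this position, in this assay: on this aromatic carbon of the five-membered aromatic ring with 3 nitrogen, 4-bromophenyl set directly on the ring and phenethyl cannot be told apart, with a 1.1-fold higher number from compound 3 to compound 4 (0.06 log units; within the scatter). Against 3-hydroxypropyl the change gives a 2.2-fold lower number from compound 2 to compound 4 (0.35 log units; beyond the scatter), so among the numbers shown, the two compounds with a six-membered aromatic ring of carbon only in this group, compound 3 and compound 4, both lie under compound 2, and that ring does not need a saturated chain to hold it here. Compound 1 remains a limit and not a number, so an at least 2.4-fold lower number from compound 1 to compound 4 (0.39 log units; beyond the scatter) stands only as a floor: the limit of > 100000 nM in this assay, at which 1 of the 4 values shown sits.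

Going by these compounds, how an unsubstituted phenyl on this carbon would compare with the 4-bromophenyl of compound 4 remains open, so the share of the bromine in this step cannot be read. Also open, on these data alone, is how an amine or a carboxylic acid at the end of a longer chain would behave here, and whether any group at this position can take the number well under that of compound 3, 35100 nM.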